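The source may hold more compounds than are shown below. What is called first, only, known or untested is meant among the compounds shown, and "the series" means these compounds.

Working notes on the series. The shared core is that of compound 1 `CC(C)C[C@H](N)c1cc(C(F)(F)F)ccc1N1CCN(C(=O)COc2ccc3ccccc3c2)CC1`, which in an assay on HEK293 cells for displacement of a labelled ligand from Melanocortin receptor 4 (Homo sapiens) (on this read-out higher numbers stand for weaker inhibition and lower numbers for stronger inhibition), gives 2000 nM. Compound 3 `CC(C)C[C@H](N)c1cc(C(F)(F)F)ccc1N1CCN(C(=O)[C@H](C)Cc2ccc(Cl)cc2)CC1` gives 31 nM in this assay. Compound 2 `CC(C)C[C@H](N)c1cc(C(F)(F)F)ccc1N1CCN(C(=O)CCC(N)=O)CC1` is the starting point of the present step; in this assay compound 2 gives > 10000 nM, which is a limit of the assay and not a number. Compound 2 thus sits at the limit of > 10000 nM in this assay, at which 1 of the 3 values shown sits. The measured steps that touch compound 2 are an at least 5.0-fold higher number from compound 1 to compound 2 (0.69 log units; beyond the scatter) and an at least 320-fold lower number from compound 2 to compound 3 (2.50 log units; beyond the scatter); both exchange the entire group on the carbonyl carbon for a much larger one and leave the amide nitrogen untouched.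

Compound 4 `CC(C)C[C@H](N)c1cc(C(F)(F)F)ccc1N1CCN(C(=O)CCC(=O)N(C)C)CC1` is not yet measured. dimethylamino in place of amino on a carbonyl carbon The 2-carbamoylethyl chain is kept and reads as 2-(dimethylcarbamoyl)ethyl afterwards. Among the compounds with values here, no measured step separates amino from dimethylamino on this carbonyl carbon, so no direction is supported by the data; the expected step is a step that the limit leaves unreadable from compound 2 to compound 4, nothing beyond the scatter. Compound 4 is therefore estimated at 15000 nM in this assay, with a range of 5000 nM to 50000 nM, and is expected most likely to be reported again only as a limit.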

Compound 4, inhibition constant: > 10000 nM
Compound 4 gave a limit, no number; the forecaster's own chance of this, stated with the estimate: 70%; the middle value does not contradict the limit.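

In this assay compound 4 gives > 10000 nM, which is a limit of the assay and not a number. The step between compound 2 and compound 4 cannot be read, so exchanging amino for dimethylamino on this carbonyl carbon, with its hydrogen-bond donor gone, brings no readable change in this assay: the limit of > 10000 nM in this assay, at which 2 of the 4 values shown sit. The 2-(dimethylcarbamoyl)ethyl chain stays far from the better groups on the carbonyl carbon, with an at least 320-fold higher number from compound 3 to compound 4 (2.50 log units; beyond the scatter) and an at least 5.0-fold higher number from compound 1 to compound 4 (0.69 log units; beyond the scatter), so capping the terminal amide does not close the gap to compound 3 or compound 1.

On these data alone, how far compound 2 and compound 4 lie from each other past the limit stays open. Also open, as far as these compounds go, is whether a carboxylic acid or a longer chain in place of the terminal amide would give a number in this assay.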